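From methylsulfanyl to isobutylamino on a shared core

A few compounds are considered here, and "the series" means these few. Any claim that something is new, unique, unknown or untested is made for them only; others in the source may bear on it.

Compound 1 (`CCCSc1nc(N)nc2c1ncn2/C=C1/CC1(CO)CO`) and compound 2 (`CSc1nc(N)nc2c1ncn2/C=C1/CC1(CO)CO`) have both been tested in an ADME assay on HFF cells (Homo sapiens) for cytotoxicity, with a stated time of 8 days; a higher number here means that more compound is tolerated, a lower number that less compound is tolerated. Compound 1 gives > 300000 nM, which is a limit and not a number. Compound 2 gives > 300000 nM, which is also a limit. Both therefore stand at the limit of > 300000 nM in this assay, at which 2 of the 2 values shown sit. Among the measured compounds shown here, the only measured step is a step that the two limits leave unreadable from compound 1 to compound 2, so it offers no size to carry forward.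

Compound 3 (`CC(C)CNc1nc(N)nc2c1ncn2/C=C1/CC1(CO)CO`) has isobutylamino in place of methylsulfanyl on an aromatic carbon, next to the ring nitrogen: isobutylamino in place of methylsulfanyl on an aromatic carbon. With no readable step as a guide, only a modest change, if any, is expected in this assay, towards less compound being tolerated, and another limit is quite possible. The estimated step is an at least 1.5-fold lower number from compound 2 to compound 3 (0.17 log units; that floor lies within the scatter). For compound 3 the expected value is 200000 nM, with an estimated range of 60000 nM to 300000 nM.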

Compound 3, half-maximal cytotoxic concentration: > 300000 nM
Compound 3: only a limit was reported; the forecaster's own chance of this, stated with the estimate: 60%; middle value at least 1.5-fold (0.17 log units) away from the limit.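

Among the compounds shown here, compound 3 also gives only a limit in this assay, so no step among compound 1, compound 2 and compound 3 can be read: (the limit of > 300000 nM in this assay, at which 3 of the 3 values shown sit). The compounds shown leave open whether propylsulfanyl, methylsulfanyl or isobutylamino on the aromatic carbon makes any difference to how much compound is tolerated.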